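Swapping the aromatic ester ring for cyclohexyl

This account rests on a few compounds, and the source may have more. Where it says the series, first, only, none or still open, it means among the compounds named here.

Among the compounds with values here, in an ADME assay on cells (Hepatocyte, Homo sapiens) for metabolic stability (on this read-out higher numbers stand for a longer-lived compound and lower numbers for a shorter-lived compound), compound 2 (`Cc1ccc(C(=O)OC2CCC(CN3CCN(c4cc(=O)c5cc(C(F)(F)F)cc([N+](=O)[O-])c5s4)CC3)CC2)cc1`) gives 0.148 h, the only true number among the measured compounds. Compound 1 (`O=C(NC1CCC(CN2CCN(c3cc(=O)c4cc(C(F)(F)F)cc([N+](=O)[O-])c4s3)CC2)CC1)c1ccccc1`) gives > 1.55 h, which is a limit of the assay. Compound 3 (`CC(=O)OC1CCC(CN2CCN(c3cc(=O)c4cc(C(F)(F)F)cc([N+](=O)[O-])c4s3)CC2)CC1`) gives < 0.15 h, also a limit. Compound 4 (`O=C(OC1CCC(CN2CCN(c3cc(=O)c4cc(C(F)(F)F)cc([N+](=O)[O-])c4s3)CC2)CC1)C1CCCCC1`) has cyclohexyl in place of 4-methylphenyl on a carbonyl carbon. Two large steps lead away from benzamido to an ester, an at least 10-fold lower number from compound 1 to compound 2 (1.02 log units; beyond the scatter) and an at least 10-fold lower number from compound 1 to compound 3 (1.01 log units; beyond the scatter). The change on the carbonyl carbon itself, a step that the limit leaves unreadable from compound 2 to compound 3, cannot be read. Since the ester stays, the expected step is a 1.0-fold higher number from compound 2 to compound 4 (0.01 log units; within the scatter), none beyond the scatter. Compound 4 is estimated at 0.15 h, with an expected range of 0.08 h to 0.35 h.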

Compound 4, half-life: 0.0967 h
Compound 4: the middle estimate sits 1.6-fold (0.19 log units) above what was measured; the range from low to high includes it.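

Within the data shown here, replacing the aromatic ring with a saturated one on the carbonyl carbon gives the first readable change at this position in this assay: a 1.5-fold lower number from compound 2 to compound 4 (0.18 log units; within the scatter), so the two esters cannot be told apart. The step away from benzamido, which starts from a limit, stays large for this ester as well, with an at least 16-fold lower number from compound 1 to compound 4 (1.20 log units; beyond the scatter). Compound 3 sits at a limit, which leaves its step to compound 4 unreadable: the limit of < 0.15 h in this assay, at which 1 of the 4 values shown sits.

On these data alone, it remains open how a urea or a sulfonamide would fare in place of the ester link. A cyclohexyl amide would show whether the amide link holds its advantage with this saturated ring.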